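Swapping the alkyne arm of compound 1 for a bromoethyl group

This account rests on a few compounds, and the source may have more. Where it says the series, first, only, none or still open, it means among the compounds named here.

Of the compounds shown here, three that share one core have been tested in a functional assay on HCT-116 cells (Homo sapiens) for inhibition, read by MTT assay, with a stated time of 48 h; on this read-out lower numbers stand for stronger inhibition and higher numbers for weaker inhibition. Compound 1 `C#CC(=O)N(Cc1ccc(OC)c(O)c1)c1cc(OC)c(OC)c(OC)c1` gives 310 nM, the lowest of the three numbers. Compound 2 `C/C=C/C(=O)N(Cc1ccc(OC)c(Br)c1)c1cc(OC)c(OC)c(OC)c1` gives 2800 nM, and compound 3 `COc1ccc(CNc2cc(OC)c(OC)c(OC)c2)cc1[N+](=O)[O-]` gives 18200 nM. Among the measured compounds shown here, both gaps to compound 1 lie beyond the usual scatter of repeated measurements, so compound 1 is the strongest inhibitor of the three measured so far. Compound 2 and compound 3 each differ from compound 1 in more than one place, so neither gap can be tied to a single structural change.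

Compound 4 `COc1ccc(CN(C(=O)C(C)Br)c2cc(OC)c(OC)c(OC)c2)cc1O` has not yet been measured. It differs from compound 1 at exactly one spot: 1-bromoethyl in place of ethynyl on a carbonyl carbon. The rest of the molecule, including the hydroxyl and methoxy groups on the benzyl side and the three methoxy groups on the core, is unchanged.

For the measured compounds named here, no measured pair with a single change is available to calibrate this step, so the expectation rests on the fact that compound 1 keeps the best number and that compound 4 keeps most of its structure. A moderate loss beyond the scatter is expected, with a 2.6-fold higher number from compound 1 to compound 4 (0.41 log units; beyond the scatter) as the estimated step. Compound 4 is therefore estimated at 800 nM, with a range from 250 nM to 2600 nM.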

Compound 4, half-maximal inhibitory concentration: 140 nM
Estimate against measurement, compound 4: 5.7-fold (0.76 log units) above, outside the stated range (below it).
By their numbers in this assay, from the lowest: compound 4; then compound 1; then compound 2; then compound 3.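

In this assay, the step of a 2.2-fold lower number from compound 1 to compound 4 (0.35 log units; beyond the scatter) shows that the ethynyl group on the carbonyl carbon is not required for the low number of compound 1. Among the compounds shown here, this is the first change at a single spot that can be read in this set, since the earlier compounds all differed from compound 1 in more than one place. It shows that an arm with no triple bond, 1-bromoethyl, can stand at this spot on the carbonyl carbon with the hydroxyl and methoxy groups of the benzyl side and the shared core left untouched, and that the number still falls by a modest but real margin. Nothing available here explains why this swap lowers the number.

On these data alone, what remains open is whether the bromine or the carbon arm that carries it accounts for the step, as this single pair cannot separate the two. A plain ethyl arm or a 1-chloroethyl arm on the same carbonyl carbon would help to pull these apart, and an amine-bearing arm would show how far this spot accepts a quite different group.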